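This account rests on a few compounds, and the source may have more. Where it says the series, first, only, none or still open, it means among the compounds named here.

Measured compounds in a functional assay on C6 cells (Rattus norvegicus) for cytotoxicity, read by MTT assay, with a stated time of 24 h, tested at 6 ug/mL; on this read-out lower numbers stand for a stronger effect and higher numbers for a weaker effect at the one concentration tested:
compound 1 `O=C(CSc1nnnn1-c1ccccc1)N/N=c1/scc(-c2ccc(Br)cc2)n1-c1ccccc1`, 61.8%
compound 2 `Cc1nnc(SCC(=O)N/N=c2/scc(-c3ccc(Cl)cc3)n2-c2ccccc2)s1`, 82.8%
compound 3 `O=C(CSc1ncccn1)N/N=c1/scc(-c2ccc(Br)cc2)n1-c1ccccc1`, 76.4%

Among these three numbers compound 1 stands lowest, that is with the strongest effect in this assay. The nearest is compound 3, reached by a number 14.6 percentage points higher from compound 1 to compound 3 (beyond the scatter), and compound 2 lies furthest off, with a number higher than that of compound 1 by more than the scatter. Going by the values given here, the one step measured, a number 14.6 percentage points higher from compound 1 to compound 3 (beyond the scatter), concerns the group on the sulfur and leaves the aryl ring untouched.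

Compound 4 `O=C(CSc1nnnn1-c1ccccc1)N/N=c1/scc(-c2ccccc2)n1-c1ccccc1` differs from compound 1 elsewhere: hydrogen in place of bromo on an aromatic carbon, read one bond further out as 4-bromophenyl to phenyl. Among the compounds with values here, no measured pair shows this change. Compound 2 carries chloro at the same place but also a different group on the sulfur, so its value alone does not separate the two changes. The expectation for compound 4 rests on a weak footing, and a step of a number 8.2 percentage points higher from compound 1 to compound 4 (within the scatter) toward a somewhat higher number is expected. Compound 4 is estimated at 70%, within 55% to 85%.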

Compound 4, a percentage reported as activity, at one concentration (the size of the read-out at that concentration, not a potency): 52.1%
Compound 4: the middle estimate sits 17.9 percentage points above what was measured; measured number below the stated range.
By their numbers in this assay, from the lowest: compounds 4 and 1 (each within the scatter of the next); then compounds 3 and 2 (each within the scatter of the next).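

In this assay, going by these compounds alone, hydrogen in place of bromo on an aromatic carbon gives a number 9.7 percentage points lower from compound 1 to compound 4 (within the scatter) with the 1-phenyl-1H-tetrazol-5-yl group on the sulfur held fixed, the first reading of this position on its own. At the one concentration tested, the 4-bromophenyl group can thus give way to phenyl with no change beyond the scatter, whereas the change on the sulfur gives a number 14.6 percentage points higher from compound 1 to compound 3 (beyond the scatter) and lies beyond it. No measured evidence speaks to the reason for this result.

Going by these compounds, it remains open whether bromo and hydrogen also read alike with pyrimidin-2-yl on the sulfur, and chloro alone cannot be read, as compound 2 differs from compound 1 in two places. Also open, on these data alone, is how an amine, a methoxy group or a carboxylic acid would read at this position.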